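A few compounds are considered here, and "the series" means these few. Any claim that something is new, unique, unknown or untested is made for them only; others in the source may bear on it.

Compound 1 `O=C1COc2ccc(-c3cnc4ccccc4c3)cc2N1C1CCCCC1` carries a cyclohexyl on an amide-type nitrogen in a ring of its core. In a functional assay on HepG2 cells (Homo sapiens) for antiproliferative activity, read by MTT assay, with a stated time of 72 h (a lower number here means a stronger inhibitor, a higher number a weaker inhibitor), compound 1 gives only a limit, > 40000 nM. Compound 2 `Cc1ccc(N2C(=O)COc3ccc(-c4cnc5ccccc5c4)cc32)cc1` differs from it by 4-methylphenyl in place of cyclohexyl on an amide-type nitrogen in a ring. In this assay compound 2 also gives only a limit, > 40000 nM. The step that the two limits leave unreadable from compound 1 to compound 2 is unreadable because both values sit at the limit of > 40000 nM in this assay, at which 2 of the 3 values shown sit. Compound 3 `O=C1COc2ccc(-c3cccc(NS(=O)(=O)c4ccc(F)cc4)c3)cc2N1C1CCCCC1` has a different core; the difference between the two cores is not broken down here. In this assay, among the measured compounds shown here, compound 3 gives 35900 nM, the only number in the set. Compound 4 `Cc1ccc(N2C(=O)COc3ccc(-c4cccc(NS(=O)(=O)c5ccc(F)cc5)c4)cc32)cc1` differs from compound 3 by 4-methylphenyl in place of cyclohexyl on an amide-type nitrogen in a ring, the same change. No measured size of that change exists to lean on. With compound 3 at 35900 nM, compound 4 is expected to show a step of a 1.4-fold higher number from compound 3 to compound 4 (0.14 log units; within the scatter). Compound 4 is estimated at 50000 nM, most likely reported only as a limit.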

Compound 4, half-maximal inhibitory concentration: > 40000 nM
Compound 4 ended at the assay's limit (the forecaster's own chance of this, stated with the estimate: 70%); the middle value lies beyond the limit too.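

In this assay, 4-methylphenyl in place of cyclohexyl on the amide-type nitrogen in a ring shows an at least 1.1-fold higher number from compound 3 to compound 4 (0.04 log units; that floor lies within the scatter). That is only a floor, and the same step on the core of compound 1 cannot be read, so the size of the change on the two cores cannot be compared because most of the values sit at one limit: the limit of > 40000 nM in this assay, at which 3 of the 4 values shown sit. The result therefore does not show whether the change carries from one core to the other with the same size, or how far it reaches on either.

The compounds shown leave open what an amine or a carboxylic acid on that nitrogen would give in this assay. They also leave open whether a morpholine or a longer chain there would give a readable number on either core.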